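The compounds below may be only part of what the source reports. "The series", "measured", "known", "first", "only" and "open" are said of these compounds alone.

Measured compounds:
compound 1, `Cc1ccc(OCC(=O)N(Cc2cccs2)CC(C)C)cc1`, 900 nM
compound 2, `Cc1ccc(OCC(=O)N(Cc2cccs2)c2ccccc2)cc1`, 23 nM
compound 3, `Cc1ccc(OCC(=O)N(CCO)Cc2cccs2)cc1`, 900 nM

All three share one core and differ only in the group carried on the amide nitrogen. In an assay on HEK293 cells for agonist activity at transient receptor potential cation channel subfamily M member 8 (Homo sapiens), read by fluorescence and calcium flux, with a stated time of 15 min (a higher number here means that more compound is needed for the effect, a lower number that less compound is needed), compound 3 stands level with compound 1, the two together giving the highest numbers of the three, and the step of no change at the digits printed from compound 1 to compound 3 (within the scatter) lies within the scatter. Compound 2 sits far away: the step of a 39-fold higher number from compound 2 to compound 3 (1.59 log units; beyond the scatter) is large, and so is a 39-fold lower number from compound 1 to compound 2 (1.59 log units; beyond the scatter).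

The unmeasured compound 4, `Cc1ccc(OCC(=O)N(Cc2cccs2)c2cnccn2)cc1`, is reached from compound 3 by one change: pyrazin-2-yl in place of 2-hydroxyethyl on an amide-type nitrogen. For the measured compounds named here, two measured steps bear on it. Both compound 1 and compound 3 carry a chain on that nitrogen and give the same high numbers, while compound 2, carrying an aromatic ring there, gives a much lower number; a 39-fold higher number from compound 2 to compound 3 (1.59 log units; beyond the scatter) shows the size of that gap. Compound 4 also places an aromatic ring on that nitrogen, though one with two nitrogen atoms rather than phenyl, so a large step downward is expected, perhaps not the full size of the phenyl step. For compound 4 the expected step is a 15-fold lower number from compound 3 to compound 4 (1.18 log units; beyond the scatter), giving an estimate of 60 nM, with a range from 15 nM to 300 nM.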

Compound 4, half-maximal effective concentration: 1240 nM
Estimate against measurement, compound 4: 21-fold (1.32 log units) below; the whole stated range lies below it.
By their numbers in this assay, from the lowest: compound 2; then compounds 1, 3 and 4 (each within the scatter of the next).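

Pyrazin-2-yl in place of 2-hydroxyethyl gives a 1.4-fold higher number from compound 3 to compound 4 (0.14 log units; within the scatter) in this assay and pyrazin-2-yl in place of isobutyl gives a 1.4-fold higher number from compound 1 to compound 4 (0.14 log units; within the scatter) on the same nitrogen, so this ring reads the same as the two chains. Pyrazin-2-yl in place of phenyl gives a 54-fold higher number from compound 2 to compound 4 (1.73 log units; beyond the scatter) at this position, which shows that a six-membered aromatic ring on the amide-type nitrogen is not enough on its own to give the low number of compound 2: the two rings are the same size, yet they lie far apart, and the 2 ring nitrogen atoms of pyrazin-2-yl are the visible difference between them. Nothing measured here explains that gap.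

The compounds shown leave open whether a pyridine ring, with a single ring nitrogen, would read like phenyl or like pyrazin-2-yl, and so how much of the gap follows from one ring nitrogen alone. They also leave open whether a saturated cyclohexyl ring on this nitrogen would read like phenyl or like the two chains.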